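Working notes on compounds 1 to 3

A few compounds are considered here, and "the series" means these few. Any claim that something is new, unique, unknown or untested is made for them only; others in the source may bear on it.

Measured so far:
compound 1 `C/N=C(/NC#N)NCCCCCn1nc(-c2ccccc2)ccc1=O` — 76.2 mg/kg
compound 2 `O=c1ccc(-c2ccccc2)nn1CCCCNC(=S)Nc1ccccc1` — > 100 mg/kg

In a functional assay on the whole organism with Rattus norvegicus as the target (on this read-out higher numbers stand for an effect only at larger amounts of compound and lower numbers for an effect already at smaller amounts), compound 1 gives 76.2 mg/kg. For compound 2 the read-out is a limit only, > 100 mg/kg, not a number. Compound 2 therefore stands at the limit of > 100 mg/kg in this assay, at which 1 of the 2 values shown sits, which fixes no value of its own.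

Compound 3 `N#CNC(=N)NCCCCn1nc(-c2ccccc2)ccc1=O` differs from compound 2 in one place: a group of 5 heavy atoms (2 carbon, 3 nitrogen; no ring) in place of a group of 9 heavy atoms (7 carbon, 1 nitrogen, 1 sulfur; one six-membered aromatic ring of carbon only), on an amine nitrogen. No measured pair covers this exchange, so the size of its step has not been shown. Compound 1 carries a group of the entering kind and gives 76.2 mg/kg, which is the only anchor here. On that basis compound 3 is expected to move off the limit, with an at least 1.4-fold lower number from compound 2 to compound 3 (0.15 log units; that floor lies within the scatter) as the estimated step. The estimate for compound 3 in this assay is 70 mg/kg, expected to fall between 25 mg/kg and 200 mg/kg.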

Compound 3, dose for half-maximal effect: 59.3 mg/kg
The estimate for compound 3 lay 1.2-fold (0.07 log units) above the measured number; measured number inside the range.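

In this assay, the exchange on the amine nitrogen gives an at least 1.6-fold lower number from compound 2 to compound 3 (0.22 log units; that floor lies within the scatter), so the first size shown for this change is only a floor, and that floor does not go beyond the scatter. Compound 2 stays a limit and not a number: the limit of > 100 mg/kg in this assay, at which 1 of the 3 values shown sits.

The exchange on the saturated chain carbon, four bonds along the chain from an aromatic nitrogen, gives a 1.3-fold lower number from compound 1 to compound 3 (0.11 log units; within the scatter), so this read-out does not separate the two compounds, and the two groups of this kind are so far interchangeable here.

From the compounds shown here alone, the true size of the step from compound 2 stays open as long as compound 2 has only a limit. Also open, going by these compounds, is how a primary amine, a carboxylic acid or a longer chain at this place would read in this assay.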